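This account rests on a few compounds, and the source may have more. Where it says the series, first, only, none or still open, it means among the compounds named here.

Of the compounds shown here, three have been measured so far in a functional assay on A549 cells (Homo sapiens) for inhibition, read by sulforhodamine B assay, with a stated time of 72 h; a lower number here means a stronger inhibitor, a higher number a weaker inhibitor. Compound 1 `COc1cc2c(Nc3ccc(F)c(Cl)c3)ncnc2cc1OCCCn1ccnc1[N+](=O)[O-]` gives 4310 nM, compound 2 `COc1cc2c(Nc3ccc(F)c(Cl)c3)ncnc2cc1OCCOCCn1ccnc1[N+](=O)[O-]` gives 7640 nM, and compound 3 `C#Cc1cccc(Nc2ncnc3cc(OCCCCn4ccnc4[N+](=O)[O-])c(OC)cc23)c1` gives 1080 nM. Compound 3 has the lowest number of the three, and its gap to each of the others lies beyond the scatter of repeated measurements, which makes it the strongest inhibitor of this small set.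

Compound 4 `C#Cc1cccc(Nc2ncnc3cc(OCCCCCn4ccnc4[N+](=O)[O-])c(OC)cc23)c1` differs from compound 3 only in the chain that carries the nitroimidazole: (2-nitro-1H-imidazol-1-yl)methyl in place of 2-nitro-1H-imidazol-1-yl on a saturated chain carbon, four bonds along the chain from an oxygen on an aromatic ring. In words, (2-nitro-1H-imidazol-1-yl)methyl stands in place of 2-nitro-1H-imidazol-1-yl on a saturated chain carbon, four bonds along the chain from an oxygen on an aromatic ring.

For the measured compounds named here, only one measured step bears on this change: a 1.8-fold higher number from compound 1 to compound 2 (0.25 log units; within the scatter), which stays within the scatter. That step also alters the chain, but it puts in 2-(2-nitro-1H-imidazol-1-yl)ethoxy, and its compounds differ from compound 3 elsewhere too, so it is only a loose guide. No step beyond the scatter is therefore expected in this assay, though a small rise in the number would not be a surprise. The expected step is a 1.2-fold higher number from compound 3 to compound 4 (0.08 log units; within the scatter). For compound 4 the estimate is 1300 nM, with an expected range from 550 nM to 3000 nM.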

Compound 4, half-maximal inhibitory concentration: 180 nM
For compound 4 the middle estimate is 7.2-fold (0.86 log units) above the measured one, outside the stated range (below it).
By their numbers in this assay, from the lowest: compound 4; then compound 3; then compounds 1 and 2 (each within the scatter of the next).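

In this assay, the step of a 6.0-fold lower number from compound 3 to compound 4 (0.78 log units; beyond the scatter) shows that the chain carrying the nitroimidazole can matter: with (2-nitro-1H-imidazol-1-yl)methyl in place of 2-nitro-1H-imidazol-1-yl on a saturated chain carbon, four bonds along the chain from an oxygen on an aromatic ring, the change lies beyond the scatter and the number falls. For the compounds shown here, the only earlier chain change, a 1.8-fold higher number from compound 1 to compound 2 (0.25 log units; within the scatter), stayed within the scatter, so it gave no sign of a shift this large, although that earlier pair carries a different chain and differs from the later pair elsewhere on the shared core. Nothing available here explains why this change lowers the number.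

On these data alone, whether a still longer chain would lower the number further or raise it again stays open, since a single step gives a difference and not a trend. Also open, as far as these compounds go, is whether the same change would lower the number on the core of compound 1, and whether an amine in place of the nitro group on the imidazole would keep the number this low.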